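Aryl Ether in Place of Benzyl Ether: Clearance Outlook

The source may hold more compounds than are shown below. What is called first, only, known or untested is meant among the compounds shown, and "the series" means these compounds.

Compound 1 `N#Cc1ccccc1COc1ccc([C@H]2CC[C@@H](C(N)=O)N2)cc1`: 1.4 mL.min-1.g-1
Compound 2 `NC(=O)[C@@H]1CC[C@H](c2ccc(OCc3ccccc3)cc2)N1`: 0.5 mL.min-1.g-1
Compound 3 `NC(=O)[C@@H]1CC[C@H](c2ccc(OCc3cccc(F)c3)cc2)N1`: a limit, < 0.5 mL.min-1.g-1

Of the compounds shown here, three sharing one core have been tested in an ADME assay on microsomes from liver (Rattus norvegicus) for metabolic stability; on this read-out higher numbers stand for fast clearance and lower numbers for slow clearance. Compound 1 gives 1.4 mL.min-1.g-1 in this assay. Compound 2, with hydrogen in place of cyano on an aromatic carbon, gives 0.5 mL.min-1.g-1, the lowest of the two numbers that were read; the step is a 2.8-fold lower number from compound 1 to compound 2 (0.45 log units; beyond the scatter). For compound 3 this assay reports only a limit, < 0.5 mL.min-1.g-1. From compound 1 that is an at least 2.8-fold lower number from compound 1 to compound 3 (0.44 log units; beyond the scatter), and from compound 2 it is a number no higher from compound 2 to compound 3 (the limit leaves the size open), so the fluoro in place of hydrogen leaves the direction open.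

Compound 4 `NC(=O)[C@@H]1CC[C@H](c2ccc(Oc3ccc(F)cc3)cc2)N1` has not yet been measured. It differs from compound 2 by 4-fluorophenyl in place of benzyl on an oxygen on an aromatic ring. Going by the values given here, no measured step changes the benzyl itself, so the steps that bear on compound 4 are those around compound 2: a 2.8-fold lower number from compound 1 to compound 2 (0.45 log units; beyond the scatter) and a number no higher from compound 2 to compound 3 (the limit leaves the size open), neither of which points to a rise. Compound 2 already sits close to the limit of < 0.5 mL.min-1.g-1 in this assay, at which 1 of the 3 values shown sits, so a further fall may not be read as a number. The expected change is a 1.1-fold higher number from compound 2 to compound 4 (0.04 log units; within the scatter). Compound 4 is therefore expected to give about 0.55 mL.min-1.g-1 in this assay, within 0.3 mL.min-1.g-1 to 1.2 mL.min-1.g-1.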

Compound 4, intrinsic clearance in microsomes: 2 mL.min-1.g-1
Beside the measured number, compound 4's estimate is 3.6-fold (0.56 log units) below it, and the stated range ends below it.
By their numbers in this assay, from the lowest: compound 2; then compounds 1 and 4 (each within the scatter of the next).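

Replacing benzyl with 4-fluorophenyl on an oxygen on an aromatic ring is the first change shown to the benzyl itself, and in this assay it gives a 4.0-fold higher number from compound 2 to compound 4 (0.60 log units; beyond the scatter). The earlier steps around compound 2 altered only what the aromatic ring of the benzyl carries, and none of them showed a rise from compound 2, so this position is the first shown where the low number of compound 2 is lost. Both groups have the same counts of heavy atoms, hydrogen-bond donors and hydrogen-bond acceptors and one six-membered aromatic ring of carbon only, and nothing measured here gives a reason for the rise.

This single step swaps the whole group, so it cannot separate the loss of the benzyl from the arrival of the fluoro, and plain phenyl or 4-fluorobenzyl on the same oxygen would be needed to tell the two apart. As far as these compounds go, it also remains open how this position responds to other groups on that oxygen, such as a pyridyl ring or a longer chain like 2-phenylethyl.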